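Methoxy on the phenyl group of compound 2

A few compounds are considered here, and "the series" means these few. Any claim that something is new, unique, unknown or untested is made for them only; others in the source may bear on it.

Within the data shown here, compound 2 (`COc1ncc(-c2ccc3c(c2)N(c2ccccc2)C(=O)CO3)cc1NS(=O)(=O)c1ccc(F)cc1`) gives 15200 nM in a functional assay on A-375 cells (Homo sapiens) for antiproliferative activity, read by MTT assay, with a stated time of 72 h (on this read-out higher numbers stand for weaker inhibition and lower numbers for stronger inhibition), the only true number so far. Compound 1 (`COc1cccc(N2C(=O)COc3ccc(-c4cnc(OC)c(NS(=O)(=O)c5ccc(F)cc5)c4)cc32)c1`) gives > 40000 nM in this assay, which is a limit of the assay and not a number.

Compound 3 (`COc1ccc(N2C(=O)COc3ccc(-c4cnc(OC)c(NS(=O)(=O)c5ccc(F)cc5)c4)cc32)cc1`) turns the phenyl of compound 2 into 4-methoxyphenyl: methoxy in place of hydrogen on an aromatic carbon, para to a large group.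

Among the measured compounds shown here, one measured step bears on this change: an at least 2.6-fold lower number from compound 1 to compound 2 (0.42 log units; beyond the scatter), with hydrogen in place of methoxy on an aromatic carbon. Going by that step, a move of similar size in the opposite direction is expected in this assay, towards a higher number and weaker inhibition. This single step is thin support. The expected step is a 2.0-fold higher number from compound 2 to compound 3 (0.30 log units; within the scatter). For compound 3 the estimated value is 30000 nM, with an expected range of 12000 nM to 70000 nM.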

Compound 3, half-maximal inhibitory concentration: 18400 nM
Estimate against measurement, compound 3: 1.6-fold (0.21 log units) above; the measured number falls inside the stated range.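

In this assay, methoxy para to a large group gives a 1.2-fold higher number from compound 2 to compound 3 (0.08 log units; within the scatter), so phenyl and 4-methoxyphenyl cannot be told apart here, and this place accepts methoxy without a change beyond the scatter. Moving the methoxy gives an at least 2.1-fold lower number from compound 1 to compound 3 (0.33 log units; beyond the scatter), which the earlier compounds could not show: the weaker result for 3-methoxyphenyl does not extend to every methoxy placement on this ring. Compound 1 stands at a limit of the assay and not at a number, so the true size of this step stays unfixed: the limit of > 40000 nM in this assay, at which 1 of the 3 values shown sits.

Open, on these data alone, is whether an amine, a carboxylic acid or a longer chain such as ethoxy at this same place would move the number beyond the scatter. Also open, as far as these compounds go, is whether a chlorine atom here would behave as methoxy does.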